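Cyclopropyl for ethyl on the amine chain of compound 2

The compounds below may be only part of what the source reports. "The series", "measured", "known", "first", "only" and "open" are said of these compounds alone.

Compound 1 `CCCN(C)c1cc(C)nc2c(-c3ccc(Cl)cc3Cl)nn(C)c12` gives 24 nM in an assay on HEK293 cells for displacement of a labelled ligand from corticotropin-releasing factor receptor 1 (Homo sapiens); on this read-out higher numbers stand for weaker inhibition and lower numbers for stronger inhibition.
Compound 2 `CCCN(CC)c1cc(C)nc2c(-c3ccc(Cl)cc3Cl)nn(C)c12` gives 4.1 nM in this assay.

Compound 2 has the lowest of the two numbers, and the step from compound 1 to it, a 5.9-fold lower number from compound 1 to compound 2 (0.77 log units; beyond the scatter), lies beyond the scatter. Compound 3 `CCN(CC1CC1)c1cc(C)nc2c(-c3ccc(Cl)cc3Cl)nn(C)c12` differs from compound 2 only by cyclopropyl in place of ethyl on a saturated chain carbon bound to a nitrogen on an aromatic ring. Among the compounds with values here, the single measured step, a 5.9-fold lower number from compound 1 to compound 2 (0.77 log units; beyond the scatter), also concerns a saturated chain carbon bound to the ring nitrogen, but it added a methyl where hydrogen stood; the present change swaps one small carbon group for another at that chain, so that step bears on it only loosely. Compound 3 is therefore expected to give a number close to that of compound 2, with the step of a 1.2-fold lower number from compound 2 to compound 3 (0.07 log units; within the scatter) expected to stay within the scatter. The estimate for compound 3 is 3.5 nM, within 1.2 nM to 10 nM.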

Compound 3, inhibition constant: 4.4 nM
The estimate for compound 3 lay 1.3-fold (0.10 log units) below the measured number; the measured number falls inside the stated range.
By their numbers in this assay, from the lowest: compounds 2 and 3 (each within the scatter of the next); then compound 1.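

Cyclopropyl in place of ethyl on a saturated chain carbon bound to a nitrogen on an aromatic ring gives, in this assay, a 1.1-fold higher number from compound 2 to compound 3 (0.03 log units; within the scatter), so this position takes a three-membered carbon ring and one more heavy atom without a shift beyond the scatter. The full amine comparison gives a 5.5-fold lower number from compound 1 to compound 3 (0.74 log units; beyond the scatter), which shows that the advantage over compound 1 is not confined to the open-chain ethyl(propyl)amino group of compound 2. Nothing shown offers an explanation for this result.

As far as these compounds go, it remains open whether a larger ring such as cyclobutylmethyl, or a longer chain such as butyl, would hold the number at this amine. From the compounds shown here alone, it is equally open how a chain carrying an ether oxygen or a hydroxyl would fare there.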